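Exchanging a Hydroxy for a Methyl on a Ring Substituent

This account rests on a few compounds, and the source may have more. Where it says the series, first, only, none or still open, it means among the compounds named here.

Compound 1 `CC[C@H]1N[C@@H](CO)[C@@H](O)[C@H](O)[C@H]1O` is the starting point of this account. In an assay on isolated protein for inhibition of uncharacterized protein (Sus scrofa), tested at 1000 uM (a lower number here means less inhibition, a higher number more inhibition at the concentration tested (going by the name of the read-out)), compound 1 gives 0%. Compound 2 `CC[C@H]1NC[C@@H](O)[C@@H](O)[C@H](O)[C@H]1O` gives 3.9% in this assay, and compound 3 `CC[C@@H]1NC[C@@H](O)[C@@H](O)[C@H](O)[C@H]1O` gives 0%. Compound 1 thus stands level with compound 3 at the digits reported, and the two together sit at the lowest of the three numbers, while compound 2 lies within the scatter of both. For the measured compounds named here, the single measured step, a number 3.9 percentage points lower from compound 2 to compound 3 (within the scatter), rests on the fact that compounds 2 and 3 differ only in the configuration as drawn and shows nothing beyond the scatter.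

Compound 4 `CC[C@@H]1N[C@H](CC)[C@H](O)[C@@H](O)[C@@H]1O` differs from compound 1 in one place: methyl in place of hydroxy on a saturated chain carbon bound to a saturated ring carbon. Going by the values given here, no measured step covers this exchange of a hydroxy for a methyl; the step from compound 2 to compound 3 concerns configuration alone and offers no guide to it. All three numbers in this assay sit near the bottom of the scale, and nothing among them points towards a rise. The step from compound 1 to compound 4 is therefore expected to be small, a number 3 percentage points higher from compound 1 to compound 4 (within the scatter), in no direction beyond the scatter. Compound 4 is estimated to give 3%, within a range from 0% to 15%.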

Compound 4, a percentage reported as inhibition, at one concentration (the size of the read-out at that concentration, not a potency): 4.9%
Compound 4: middle estimate off by 1.9 percentage points, on the low side, within the range that was stated.
By their numbers in this assay, from the lowest: compounds 1, 3, 2 and 4 (each within the scatter of the next).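

In this assay, for the compounds shown here, the exchange of hydroxy for methyl on a saturated chain carbon bound to a saturated ring carbon, a kind of change the earlier compounds did not cover, comes to a number 4.9 percentage points higher from compound 1 to compound 4 (within the scatter). At this position, then, going from hydroxymethyl to ethyl takes away the hydrogen-bond donor and acceptor counted for the hydroxy without moving the read-out beyond the scatter, so this exchange of groups shows no more than the earlier change of configuration did. Nothing in the information available accounts for this result.

What the compounds shown leave open is whether any other group at this place, such as an amine, a carboxylic acid or a longer chain, would carry the number in this assay beyond the scatter. Since every step shown lies within the scatter at a single concentration, they also leave open whether hydroxy and methyl at this position would differ in a series where the read-out stands clear of the bottom of the scale.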